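The source may report more compounds than this note shows. Statements on the series, on what has been measured and on what is new or still open speak of the compounds shown alone.

Of the compounds shown here, three of one series have been measured in a functional assay on HeLa cells (Homo sapiens) for antiproliferative activity, read by MTT assay, with a stated time of 48 h; a lower number here means a stronger inhibitor, a higher number a weaker inhibitor. Compound 1 `O=C(CCl)Nc1ccc(SCC(=O)Nc2cc(Cl)ccn2)cc1` gives in this assay a value of 2800 nM. Among the compounds with values here, compound 2 `O=C(CCCl)Nc1ccc(SCC(=O)Nc2cc(Cl)ccn2)cc1` gives in this assay a value of 21700 nM, and the only step between two measured compounds is a 7.8-fold higher number from compound 1 to compound 2 (0.89 log units; beyond the scatter). Compound 3 `CC(C)(C)C(=O)Nc1ccc(SCC(=O)Nc2ccc(Cl)cn2)cc1` carries a different acyl group on the first amide and a different chloropyridine on the second. In this assay compound 3 reaches only the limit of the assay, > 80000 nM, and so is known only to stand at the weak end of the three values shown, as noted in the limit of > 80000 nM in this assay, at which 1 of the 3 values shown sits.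

Compound 4 `CC(C)(C)C(=O)Nc1ccc(SCC(=O)Nc2cc(Cl)ccn2)cc1` has the same atoms as compound 3, joined differently: 4-chloropyridin-2-yl in place of 5-chloropyridin-2-yl on an amide-type nitrogen. Within the data shown here, no measured step bears on this change; the single measured step, a 7.8-fold higher number from compound 1 to compound 2 (0.89 log units; beyond the scatter), concerns the chain on the other amide, and compounds 1 and 2 carry the 4-chloropyridin-2-yl group that enters in compound 4, while compound 3 alone carries the 5-chloropyridin-2-yl group. Compound 4 also keeps the acyl group of compound 3. The step of a number no higher from compound 3 to compound 4 (the limit leaves the size open) is therefore expected to lie within the scatter, with a value again near the limit. Compound 4 is expected to give 80000 nM, between 20000 nM and 300000 nM.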

Compound 4, half-maximal inhibitory concentration: > 80000 nM
Compound 4 gave a limit, no number; the forecaster's own chance of this, stated with the estimate: 60%; the middle value lies on the limit itself.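

With the 4-chloropyridin-2-yl group held fixed, the acyl group can now be read on its own, and tert-butyl on the carbonyl carbon gives an at least 28-fold higher number from compound 1 to compound 4 (1.45 log units; beyond the scatter) and an at least 3.6-fold higher number from compound 2 to compound 4 (0.56 log units; beyond the scatter). In this assay compound 4 gives a limit of the assay and not a number, > 80000 nM, so the tert-butyl amide falls off from both chloroalkyl amides by more than the scatter, with the full size of each step left open. The change from 5-chloropyridin-2-yl to 4-chloropyridin-2-yl on the amide-type nitrogen cannot be read, since compound 3 and compound 4 both sit at the limit: the limit of > 80000 nM in this assay, at which 2 of the 4 values shown sit.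

The compounds shown leave open how the 5-chloropyridin-2-yl group behaves with a chloromethyl or 2-chloroethyl chain on the carbonyl carbon, where measured values could show a difference between the two chloropyridines. They also leave open whether the chlorine of the chain is what separates compound 1 and compound 2 from compound 4, which a plain methyl or ethyl group on the carbonyl carbon would test.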